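Substituent exchange on the pendant phenyl ring: compound 4

A few compounds are considered here, and "the series" means these few. Any claim that something is new, unique, unknown or untested is made for them only; others in the source may bear on it.

Compound 3 `CCCS(=O)(=O)Nc1ccc(F)c(C(=O)c2n[nH]c3ncc(-c4ccc(S(C)(=O)=O)cc4)cc23)c1F` stands lowest of the three measured compounds in an assay for binding affinity to dual specificity mitogen-activated protein kinase kinase 4 (Homo sapiens), read by KINOMEscan, tested at 100 nM (on this read-out higher numbers stand for a weaker effect at the one concentration tested and lower numbers for a stronger effect), at 1.5%. Compound 1 `CCCS(=O)(=O)Nc1ccc(F)c(C(=O)c2n[nH]c3ncc(-c4ccc(Cl)c(Cl)c4)cc23)c1F` gives 45%, and compound 2 `CCCS(=O)(=O)Nc1ccc(F)c(C(=O)c2n[nH]c3ncc(-c4cccc([N+](=O)[O-])c4)cc23)c1F` gives 15%. The steps of a number 43.5 percentage points lower from compound 1 to compound 3 (beyond the scatter) and a number 13.5 percentage points lower from compound 2 to compound 3 (beyond the scatter) each exchange the whole pendant aryl group, as does a number 30 percentage points lower from compound 1 to compound 2 (beyond the scatter). Compound 4 `CCCS(=O)(=O)Nc1ccc(F)c(C(=O)c2n[nH]c3ncc(-c4ccc(C(N)=O)cc4)cc23)c1F` keeps the aryl ring of compound 3 and alters only its substituent: carbamoyl in place of methylsulfonyl on an aromatic carbon. Among the compounds with values here, no measured step bears directly on this exchange; the expectation therefore rests on compound 3 alone, whose value is 1.5%. Only a small step in this assay is expected, if any, more likely upward than downward. Compound 4 is estimated at 8%, within 1.5% to 30%, the expected step being a number 6.5 percentage points higher from compound 3 to compound 4 (within the scatter).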

Compound 4, a percentage reported as activity, at one concentration (the size of the read-out at that concentration, not a potency): 0.15%
For compound 4 the middle estimate is 7.9 percentage points above the measured one; the measured number lies below the stated range.
By their numbers in this assay, from the lowest: compounds 4 and 3 (each within the scatter of the next); then compound 2; then compound 1.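

In this assay, carbamoyl in place of methylsulfonyl on this aromatic carbon, para to a large group, leaves the read-out within the scatter (a number 1.4 percentage points lower from compound 3 to compound 4 (within the scatter)), although carbamoyl carries a hydrogen-bond donor and methylsulfonyl carries none. The 4-carbamoylphenyl group also stands clear of the other two aryl groups (a number 14.9 percentage points lower from compound 2 to compound 4 (beyond the scatter)) and (a number 44.9 percentage points lower from compound 1 to compound 4 (beyond the scatter)). No evidence on the cause of these steps is available.

From the compounds shown here alone, whether a carboxylic acid or an amine on this carbon would read like carbamoyl remains open. Also open, going by these compounds, is whether compound 3 and compound 4 would separate at a lower concentration.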